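This account rests on a few compounds, and the source may have more. Where it says the series, first, only, none or still open, it means among the compounds named here.

The study concerns four nucleoside-like compounds that share a fused two-ring core and differ in two places: the substituent on the aromatic carbon of the five-membered ring and the group on the six-membered ring. Compound 3 `COc1ncnc2c1c(-c1cc3ccccc3o1)cn2[C@@H]1O[C@H](CO)[C@@H](O)[C@H]1O` carries a 1-benzofuran-2-yl group and a methoxy group, compound 1 `COc1ncnc2c1c(-c1ccccc1)cn2[C@@H]1O[C@H](CO)[C@@H](O)[C@H]1O` the same methoxy group with phenyl in its place, compound 2 `O=c1[nH]cnc2c1c(-c1cc3ccccc3o1)cn2[C@@H]1O[C@H](CO)[C@@H](O)[C@H]1O` the 1-benzofuran-2-yl group on an oxo-bearing core, and compound 4 `O=c1[nH]cnc2c1c(-c1ccccc1)cn2[C@@H]1O[C@H](CO)[C@@H](O)[C@H]1O` the phenyl group on that same oxo-bearing core. The difference between the cores of compound 2 and compound 3 is not broken down here.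

In an ADME assay on MRC5 cells (Homo sapiens), read by MTT assay, with a stated time of 72 h (on this read-out higher numbers stand for weaker inhibition and lower numbers for stronger inhibition), compound 3 gives 65600 nM. For compound 1 this assay reports only a limit, > 100000 nM. For compound 2 the result is likewise a limit, > 100000 nM. The change phenyl in place of 1-benzofuran-2-yl on an aromatic carbon therefore produced an at least 1.5-fold higher number from compound 3 to compound 1 (0.18 log units; that floor lies within the scatter), a step whose floor is set by the limit of > 100000 nM in this assay, at which 2 of the 3 values shown sit.

The change from compound 2 to compound 4 is the same one, (phenyl in place of 1-benzofuran-2-yl on an aromatic carbon), made on the other core. Within the data shown here, since the value of compound 2 already sits at the limit of this assay, and the one measured instance of this change moved the number upward rather than downward, compound 4 is expected to return a number no lower than that of compound 2, an expected step that the limit leaves unreadable from compound 2 to compound 4. The estimate for compound 4 in this assay is accordingly 200000 nM, with an expected range from 100000 nM to 1000000 nM, most probably reported again only as a limit.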

Compound 4, half-maximal inhibitory concentration: > 100000 nM
Compound 4 gave a limit, no number; the forecaster's own chance of this, stated with the estimate: 90%; the middle value is on the limit's open side.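

In this assay compound 4, like compound 2, returns only a limit and no number, so the step between these two compounds cannot be read: the limit of > 100000 nM in this assay, at which 3 of the 4 values shown sit.

The compounds shown leave open what numbers compound 1, compound 2 and compound 4 would give in this assay, and so whether phenyl in place of 1-benzofuran-2-yl changes the result on the oxo-bearing core at all.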